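Sulfur-linked benzyl series: 4-fluorobenzyl to 2-bromobenzyl

The source may hold more compounds than are shown below. What is called first, only, known or untested is meant among the compounds shown, and "the series" means these compounds.

Measured so far in a functional assay on HepG2 cells (Homo sapiens) for antiproliferative activity, read by MTT assay, with a stated time of 24 h; a higher number here means a weaker inhibitor, a lower number a stronger inhibitor
compound 1 `Sc1nnc(-c2ccc3c(c2)OCCO3)n1-c1ccccc1` gives 60000 nM
compound 2 `c1ccc(CSc2nnc(-c3ccc4c(c3)OCCO4)n2-c2ccccc2)cc1` gives 5960 nM
compound 3 `Fc1ccc(CSc2nnc(-c3ccc4c(c3)OCCO4)n2-c2ccccc2)cc1` gives 1020 nM

Within the data shown here, compound 3 (1020 nM) holds the lowest number of the series in this assay so far. The next compound is compound 4 `Brc1ccccc1CSc1nnc(-c2ccc3c(c2)OCCO3)n1-c1ccccc1`, with 2-bromophenyl in place of 4-fluorophenyl on a saturated chain carbon bound to a sulfur.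

Among the measured compounds shown here, three measured steps bear on this change. Benzyl on the sulfur gave a 10-fold lower number from compound 1 to compound 2 (1.00 log units; beyond the scatter), and 4-fluorobenzyl gave a 59-fold lower number from compound 1 to compound 3 (1.77 log units; beyond the scatter). Compound 4 keeps a benzyl group on the sulfur, so it is expected to stay far from compound 1. The fluoro alone gave a 5.8-fold lower number from compound 2 to compound 3 (0.77 log units; beyond the scatter), and that gain may be only partly kept once the fluoro is gone. For the measured compounds named here, no measured compound carries bromo, so a modest rise in the number is expected, not a further fall.

The estimated move is a 2.5-fold higher number from compound 3 to compound 4 (0.39 log units; beyond the scatter) in this assay. For compound 4 the expected value is 2500 nM, with an estimated range of 700 nM to 9000 nM.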

Compound 4, half-maximal inhibitory concentration: 4730 nM
For compound 4 the middle estimate is 1.9-fold (0.28 log units) below the measured one; the range from low to high includes it.
By their numbers in this assay, from the lowest: compound 3; then compounds 4 and 2 (each within the scatter of the next); then compound 1.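

In this assay, 2-bromophenyl in place of 4-fluorophenyl gives a 4.6-fold higher number from compound 3 to compound 4 (0.67 log units; beyond the scatter) and so does not keep the gain seen with the 4-fluorobenzyl group. Bromo in place of hydrogen on the benzyl group gives a 1.3-fold lower number from compound 2 to compound 4 (0.10 log units; within the scatter) and so leaves compound 4 level with compound 2, while 2-bromobenzyl in place of hydrogen on the sulfur still gives a 13-fold lower number from compound 1 to compound 4 (1.10 log units; beyond the scatter) as the step from the free sulfur compound. No measurement at hand explains the difference between the fluoro and bromo compounds.

The halogen and its ring position both change from compound 3 to compound 4, so these compounds cannot separate the two; 4-bromobenzyl and 2-fluorobenzyl would do so. Also open, on these data alone, is how a methoxy group or a nitrile on the benzyl ring would compare with 4-fluorobenzyl.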